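From 4-methoxyphenyl to thiophen-2-yl on a shared core

The compounds below may be only part of what the source reports. "The series", "measured", "known", "first", "only" and "open" are said of these compounds alone.

In a functional assay on microsomes for inhibition, with a stated time of 1 h (on this read-out lower numbers stand for stronger inhibition and higher numbers for weaker inhibition), compound 1 (`CCOC(=O)c1cnn(-c2nc(-c3ccc(OC)cc3)c(C#N)c(=O)n2C)c1N`) gives 68 ug/mL. Within the data shown here, the only other measured compound, compound 2 (`COc1cccc(-c2nc(NN)n(C)c(=O)c2C#N)c1OC`), gives 37 ug/mL. The gap between these two numbers lies within the usual scatter of repeated measurements, so the two compounds cannot be told apart on this read-out.

Compound 3 (`CCOC(=O)c1cnn(-c2nc(-c3cccs3)c(C#N)c(=O)n2C)c1N`) has not yet been measured. It keeps the core of compound 1 but carries thiophen-2-yl in place of 4-methoxyphenyl on an aromatic carbon. Among the measured compounds shown here, compound 1 and compound 2 differ in more than one place, so no measured pair shows what this swap does in this assay. With no evidence favouring either direction, the best expectation is no shift beyond the scatter. The expected change is a 1.1-fold lower number from compound 1 to compound 3 (0.05 log units; within the scatter), and this small estimated step carries real uncertainty. The estimated value for compound 3 is 60 ug/mL, with an expected range of 22 ug/mL to 150 ug/mL.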

Compound 3, half-maximal inhibitory concentration: 97 ug/mL
Estimate against measurement, compound 3: 1.6-fold (0.21 log units) below, within the range that was stated.
By their numbers in this assay, from the lowest: compounds 2, 1 and 3 (each within the scatter of the next, the first and the last beyond it).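

In this assay, among these compounds, putting thiophen-2-yl in place of 4-methoxyphenyl gives a 1.4-fold higher number from compound 1 to compound 3 (0.15 log units; within the scatter) and is the first single-place comparison available at this position, on the aromatic carbon ortho to a cyano group. The two compounds cannot be told apart on this read-out, so a five-membered aromatic ring with 5 heavy atoms, one of them sulfur, can stand here in place of a six-membered carbon ring carrying a methoxy group, 8 heavy atoms in all, with no shift that can be read. Nothing measured on these compounds explains this outcome.

Going by these compounds, both groups seen at this position are aromatic rings, so it remains open whether a non-aromatic group, such as a cyclohexyl ring, a simple amine or a longer alkyl chain, would move the number beyond the scatter. Among the compounds shown here, with only one step at this position, it also remains open whether the same swap would give a similar result on a different core, such as that of compound 2.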